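From a bromine to a nitro group on the same ring

This account rests on a few compounds, and the source may have more. Where it says the series, first, only, none or still open, it means among the compounds named here.

Three compounds share one core and differ only in the group on one of the aromatic rings. Compound 1 `Nc1scc(-c2cccc(C(F)(F)F)c2)c1C(=O)c1ccc(Cl)cc1` carries a trifluoromethyl group and gives 64% in a functional assay on CHO cells for agonist activity at adenosine receptor A1 (Homo sapiens), read by fluorescence and ERK phosphorylation, with stated times of 30 min and 1.5 h, tested at 3 uM; a higher number here means a stronger effect of the compound at the concentration tested, a lower number a weaker effect. Compound 2 `Nc1scc(-c2cccc(Cl)c2)c1C(=O)c1ccc(Cl)cc1` carries a chlorine and gives 58%. Compound 3 `Nc1scc(-c2cccc(Br)c2)c1C(=O)c1ccc(Cl)cc1` carries a bromine and gives 62%, which places it second of the three, with a number 2 percentage points lower from compound 1 to compound 3 (within the scatter) and a number 4 percentage points higher from compound 2 to compound 3 (within the scatter). Within the data shown here, the step of a number 6 percentage points lower from compound 1 to compound 2 (within the scatter) completes the picture: every swap at this position so far has left the read-out essentially where it was.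

Compound 4 `Nc1scc(-c2cccc([N+](=O)[O-])c2)c1C(=O)c1ccc(Cl)cc1` is the next swap at this spot: nitro in place of bromo on an aromatic carbon. Among the measured compounds shown here, no measured step involves a nitro group, so the only guide is that the three earlier swaps all stayed within the scatter. The expectation is therefore a step of a number 6 percentage points lower from compound 3 to compound 4 (within the scatter), not clearly beyond the scatter in either direction, with extra uncertainty because a nitro group has not been tried here. Compound 4 is estimated to give 56%, within a range from 36% to 74%.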

Compound 4, a percentage reported as activity, at one concentration (the size of the read-out at that concentration, not a potency): 53%
The estimate for compound 4 lay 3 percentage points above the measured number, within the range that was stated.
By their numbers in this assay, from the lowest: compounds 4, 2, 3 and 1 (each within the scatter of the next, the first and the last beyond it).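

In this assay, among these compounds, the nitro group brings the first step at this position that passes the scatter, though only modestly: a number 11 percentage points lower from compound 1 to compound 4 (beyond the scatter) is the one comparison that separates it, and it is with trifluoromethyl. Against the two halogens it does not stand apart, with a number 9 percentage points lower from compound 3 to compound 4 (within the scatter) and a number 5 percentage points lower from compound 2 to compound 4 (within the scatter) both showing no clear change, so a group of three heavy atoms with two hydrogen-bond acceptors can replace bromo here and compound 4 still gives 53% at the tested concentration. Nothing measured here accounts for the gap from trifluoromethyl.

As far as these compounds go, whether an amine or a carboxylic acid at this position would shift the read-out further remains open. Each number also comes from a single concentration, so it shows only how strong or weak the effect of each compound is at that concentration.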